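Changing the Side Group on an Amine Nitrogen

The source may report more compounds than this note shows. Statements on the series, on what has been measured and on what is new or still open speak of the compounds shown alone.

Measured so far:
- compound 1 `N#CC1=C(NCC(=O)O)N(c2ccccc2)C(=O)N2CCCCC(N3CCCC3)C12`: 89.2%
- compound 2 `CCOC(=O)C(=O)NC1=C(C#N)C2C(N3CCCC3)CCCCN2C(=O)N1c1ccccc1`: 91.5%

In a functional assay on the whole organism (strain albino) for inhibition, with Rattus norvegicus as the target, read by paw edema, with stated times of 1 h and 3 h, at a dose of 20 mmol/kg by the intraperitoneal route (on this read-out lower numbers stand for a weaker effect and higher numbers for a stronger effect at the one dose given), compound 2 gives 91.5%. This is the higher of the two numbers, yet the step of a number 2.3 percentage points higher from compound 1 to compound 2 (within the scatter) lies within the scatter, so the two compounds cannot be ranked. Compound 3 `N#CC1=C(NCC(=O)N2CCCCC2)N(c2ccccc2)C(=O)N2CCCCC(N3CCCC3)C12` carries the change (((piperidin-1-yl)carbonyl)methyl in place of (ethoxycarbonyl)carbonyl on an amine nitrogen). For the measured compounds named here, the only step that bears on this position, from compound 1 to compound 2, was small. A step of similar small size, in no clear direction, is therefore expected for a number 3.5 percentage points lower from compound 2 to compound 3 (within the scatter). Compound 3 is estimated at 88%, within 76% to 96%.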

Compound 3, a percentage reported as inhibition, in the whole organism at one dose (the size of the read-out at that dose, not a potency): 53.5%
Compound 3: the middle estimate sits 34.5 percentage points above what was measured; measured number outside the range, below it.
By their numbers in this assay, from the lowest: compound 3; then compounds 1 and 2 (each within the scatter of the next).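

This position is not indifferent to its side group: carboxymethyl and (ethoxycarbonyl)carbonyl could not be told apart, yet ((piperidin-1-yl)carbonyl)methyl gives a number 38 percentage points lower from compound 2 to compound 3 (beyond the scatter). The cleanest comparison is piperidin-1-yl in place of hydroxy on the carbonyl carbon, which gives a number 35.7 percentage points lower from compound 1 to compound 3 (beyond the scatter), so a change at that one carbonyl carbon is enough for a large loss. Nothing measured here speaks to the reason for this loss.

On these data alone, it remains open whether an ethyl ester or a smaller amine such as dimethylamino on that carbonyl would keep the higher numbers, or whether morpholine would behave like piperidine.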